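This account rests on a few compounds, and the source may have more. Where it says the series, first, only, none or still open, it means among the compounds named here.

The measured compounds are these: compound 1 `Cc1cc2ncn(-c3ccc4c(N)nc(N)nc4c3)c2cc1C`, which in an assay on isolated protein for inhibition of Dihydrofolate reductase (Homo sapiens), read by spectrophotometry, using NADPH, with a stated time of 10 min (on this read-out higher numbers stand for weaker inhibition and lower numbers for stronger inhibition), gives 1610 nM; compound 2 `Cc1cc2nc(-c3nccs3)n(-c3ccc4c(N)nc(N)nc4c3)c2cc1C`, which gives 93 nM; and compound 3 `Cc1cc2nc(-c3cccs3)n(-c3ccc4c(N)nc(N)nc4c3)c2cc1C`, which gives 1030 nM.

Compound 3 stands second highest of the three numbers. Its nearest neighbour is compound 1, and the two are close: a 1.6-fold lower number from compound 1 to compound 3 (0.19 log units; within the scatter). Its furthest neighbour is compound 2, and that gap is large: an 11-fold higher number from compound 2 to compound 3 (1.04 log units; beyond the scatter).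

Compound 4 `Cc1cc2nc(-c3cncn3C)n(-c3ccc4c(N)nc(N)nc4c3)c2cc1C` is not yet measured. It differs from compound 3 in one place: 1-methyl-1H-imidazol-5-yl in place of thiophen-2-yl on an aromatic carbon.

The step that bears most on this change is the one between the two five-membered rings already measured, an 11-fold higher number from compound 2 to compound 3 (1.04 log units; beyond the scatter), which shows that exchanging one ring atom in this group can shift the number by a large amount. The step of a 17-fold lower number from compound 1 to compound 2 (1.24 log units; beyond the scatter) shows how far the group can reach in the favourable direction. The new group carries two ring nitrogens, unlike either measured ring, so the direction is uncertain; compound 4 is expected to lie between compound 3 and compound 2, with a step of a 2.6-fold lower number from compound 3 to compound 4 (0.41 log units; beyond the scatter). The estimate for compound 4 is 400 nM, expected between 90 nM and 1800 nM.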

Compound 4, inhibition constant: 2920 nM
Beside the measured number, compound 4's estimate is 7.3-fold (0.86 log units) below it, outside the stated range (above it).
By their numbers in this assay, from the lowest: compound 2; then compounds 3, 1 and 4 (each within the scatter of the next, the first and the last beyond it).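

In this assay, 1-methyl-1H-imidazol-5-yl on this carbon stays within the scatter of plain hydrogen, at a 1.8-fold higher number from compound 1 to compound 4 (0.26 log units; within the scatter), so this ring keeps none of the gain that 1,3-thiazol-2-yl gives here. It also stands apart from both measured rings, with a 2.8-fold higher number from compound 3 to compound 4 (0.45 log units; beyond the scatter) against thiophen-2-yl and a 31-fold higher number from compound 2 to compound 4 (1.50 log units; beyond the scatter) against 1,3-thiazol-2-yl, which shows that a nitrogen in the ring does not by itself bring the number down. No measurement given here accounts for these differences.

As far as these compounds go, it remains open whether the methyl on the new ring matters, which an unmethylated imidazol-2-yl or an oxazol-2-yl would address. Also open, from the compounds shown here alone, is how a pyridin-2-yl ring, an amine or a short alkyl chain on this carbon would compare with 1,3-thiazol-2-yl.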